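Fluoro to Bromo on the Aryl Ether of Compound 1

The source may hold more compounds than are shown below. What is called first, only, known or untested is meant among the compounds shown, and "the series" means these compounds.

Going by the values given here, compound 1, `NC1=NC2(CCOCC2)N(OCCCOc2ccc(F)cc2)C(N)=N1`, is the weakest inhibitor of the three compounds measured so far: in a functional assay on A549 cells (Homo sapiens) for antiproliferative activity, read by MTT assay, with a stated time of 72 h (a higher number here means a weaker inhibitor, a lower number a stronger inhibitor), compound 1 gives 1060 nM, a number that lies beyond the scatter above both other compounds. Compound 2, `NC1=NC2(CCSCC2)N(OCCCOc2ccccc2Br)C(N)=N1`, gives 40 nM in this assay, and compound 3, `NC1=NC2(CCSCC2)N(OCCCOc2ccccc2Cl)C(N)=N1`, gives 80 nM. Compound 4, `NC1=NC2(CCOCC2)N(OCCCOc2ccc(Br)cc2)C(N)=N1`, differs from compound 1 in a single place: bromo in place of fluoro on an aromatic carbon. Among the compounds with values here, only one measured step exchanges one halogen for another, a 2.0-fold higher number from compound 2 to compound 3 (0.30 log units; within the scatter), and that step sits on a different core and at a different place of the ring, so it bears on the present change only loosely. Within the data shown here, no measured pair exchanges fluoro for bromo directly. Compound 2 and compound 3 differ from compound 1 in more than one place, so their values alone cannot be read as a step. Compound 4 is therefore expected to move toward a lower number, a 2.4-fold lower number from compound 1 to compound 4 (0.37 log units; beyond the scatter), by an amount that may well stay within the scatter. The estimate for compound 4 is 450 nM, with a range from 120 nM to 1700 nM.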

Compound 4, half-maximal inhibitory concentration: 280 nM
Compound 4: the middle estimate sits 1.6-fold (0.21 log units) above what was measured; the range from low to high includes it.
By their numbers in this assay, from the lowest: compounds 2 and 3 (each within the scatter of the next); then compound 4; then compound 1.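

Going by these compounds alone, this is the first exchange of fluoro for bromo with the shared core held fixed: on an aromatic carbon of a six-membered aromatic ring of carbon only, para to a large group, this assay records a 3.8-fold lower number from compound 1 to compound 4 (0.58 log units; beyond the scatter). The earlier halogen step, a 2.0-fold higher number from compound 2 to compound 3 (0.30 log units; within the scatter), stayed within the scatter on a different core, whereas this one lies beyond it, so the choice of halogen on this carbon does register in the read-out, if modestly. No measurement on hand accounts for the size or direction of this step.

The compounds shown leave open whether the same exchange would read alike on the core of compound 2, and whether chloro on this carbon would fall nearer to fluoro or to bromo. They also leave open how an amine, a methoxy group or a carboxylic acid would read on this carbon.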